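A few compounds are considered here, and "the series" means these few. Any claim that something is new, unique, unknown or untested is made for them only; others in the source may bear on it.

In a functional assay on the whole organism for inhibition, with Rattus norvegicus as the target, in the maximal electroshock model, at a dose of 25 mg/kg by the intraperitoneal route (on this read-out higher numbers stand for more inhibition at the one dose given (going by the name of the read-out) and lower numbers for less inhibition), three compounds built on a shared core have been measured so far. Compound 1 `C[C@H](c1ccccc1)n1cnc2c(N(C)C)ncnc21` gives 33%, compound 2 `c1ccc(Cn2cnc3c(N4CCC4)ncnc32)cc1` gives 17%, and compound 3 `CN(C)c1ncnc2c1ncn2Cc1ccc(Cl)cc1` gives 0%. Compound 3 thus stands lowest of the three, beyond the scatter below compound 2 and further still below compound 1. Compound 4 `Cc1ccc(Cn2cnc3c(N(C)C)ncnc32)cc1` keeps the core of compound 3 and differs from it in one place: methyl in place of chloro on an aromatic carbon. For the measured compounds named here, no measured pair shows this change, so nothing in the data fixes its size. The step is expected to be small and upward, a number 10 percentage points higher from compound 3 to compound 4 (within the scatter), hardly beyond the scatter. Compound 4 is therefore estimated at 10%, in a range from 0% to 30%.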

Compound 4, a percentage reported as inhibition, in the whole organism at one dose (the size of the read-out at that dose, not a potency): 0%
Estimate against measurement, compound 4: 10 percentage points above; measured number inside the range.
By their numbers in this assay, from the lowest: compounds 3 and 4 (each within the scatter of the next); then compound 2; then compound 1.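

For the compounds shown here, the step of no change at the digits printed from compound 3 to compound 4 (within the scatter) in this assay is the first reading of this position, on an aromatic carbon para to a large group, and it concerns methyl in place of chloro. With both compounds at the bottom of this read-out, the pair shows only that methyl does not lift the number clear of the scatter, not that the group at this position is without influence. Nothing at hand bears on why the two groups read alike.

Going by these compounds, what remains open is whether a methoxy group, an amine or a carboxylic acid at this place would read any differently. On these data alone, it is also open whether either group would matter on a compound that reads higher to begin with.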